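Dropping the Piperidinylmethyl Group from Compound 2

A few compounds are considered here, and "the series" means these few. Any claim that something is new, unique, unknown or untested is made for them only; others in the source may bear on it.

Three ureas built on one shared core were compared in a functional assay on A549 cells (Homo sapiens) for antiproliferative activity, read by MTT assay, with a stated time of 72 h; a higher number here means a weaker inhibitor, a lower number a stronger inhibitor. Compound 1 `CN1CCN(Cc2ccc(NC(=O)Nc3ccc4ncnc(Nc5ccc(F)c(Cl)c5)c4c3)cc2)CC1` gives 3480 nM. Compound 3 `C#Cc1cccc(Nc2ncnc3ccc(NC(=O)Nc4ccc(CN(CC)CC)cc4)cc23)c1` gives 2250 nM. Compound 2 `O=C(Nc1ccc(CN2CCCCC2)cc1)Nc1ccc2ncnc(Nc3cccc(C(F)(F)F)c3)c2c1` gives 1050 nM, the lowest of the three numbers; compound 3 sits above it and compound 1 further above it, both gaps lying beyond the scatter of this assay.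

Compound 4 `O=C(Nc1ccccc1)Nc1ccc2ncnc(Nc3cccc(C(F)(F)F)c3)c2c1` has not yet been measured in this assay. It differs from compound 2 in one place: hydrogen in place of (piperidin-1-yl)methyl on an aromatic carbon. Among the compounds with values here, no pair of measured compounds differs only in this way, so the size of the step cannot be read off directly. Within the data shown here, all three measured compounds carry an amine-bearing substituent on that ring, and compound 4 is the first without one. The step from compound 2 is expected to weaken inhibition by a moderate amount, with a 2.4-fold higher number from compound 2 to compound 4 (0.38 log units; beyond the scatter) as the expected change. Compound 4 is therefore estimated at 2500 nM in this assay, with a likely range from 800 nM to 8000 nM.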

Compound 4, half-maximal inhibitory concentration: > 10000 nM
Compound 4: only a limit was reported; the forecaster's own chance of this, stated with the estimate: 5%; at least 4.0-fold (0.60 log units) between middle value and limit.
By their numbers in this assay, from the lowest: compound 2; then compounds 3 and 1 (each within the scatter of the next). At a limit, above all of these: compound 4.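

In this assay, within the data shown here, the change from (piperidin-1-yl)methyl to hydrogen gives the first step that can be read at this position, para to a large group: an at least 9.5-fold higher number from compound 2 to compound 4 (0.97 log units; beyond the scatter). Compound 4 gave only a limit, > 10000 nM, so this step has a known minimum but no known full size. The earlier compounds all carried an amine-bearing substituent here and differed from each other in more than one place, whereas this pair ties a large loss of activity to this one substituent, with the reading capped by the assay: the limit of > 10000 nM in this assay, at which 1 of the 4 values shown sits.

Which part of the (piperidin-1-yl)methyl group matters remains open, and a cyclohexylmethyl or a plain methyl group at this position would separate the ring nitrogen from the carbon framework. No steps can be read among compounds 1, 2 and 3.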